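Exchanging a Chain for a Ring on Compound 2

A few compounds are considered here, and "the series" means these few. Any claim that something is new, unique, unknown or untested is made for them only; others in the source may bear on it.

Compound 1 `CN1CCN(CCCCCn2c3c(c4ccccc42)C(=O)c2c[n+]([O-])c4ccccc4c2C3=O)CC1` gives 870 nM in a functional assay on A549 cells (Homo sapiens) for cytotoxicity, read by MTT assay, with a stated time of 72 h; a lower number here means a stronger inhibitor, a higher number a weaker inhibitor.
Compound 2 `O=C1c2c[n+]([O-])c3ccccc3c2C(=O)c2c1c1ccccc1n2Cc1cn(C[C@@H](O)CO)nn1` gives 390 nM in this assay.

Among the compounds with values here, of the two measured compounds, compound 2 has the lower number; the only measured step is a 2.2-fold lower number from compound 1 to compound 2 (0.35 log units; beyond the scatter), a modest change. Compound 3 `O=C1c2c[n+]([O-])c3ccccc3c2C(=O)c2c1c1ccccc1n2Cc1cn([C@@H]2C[C@H](O)[C@@H](CO)O2)nn1` differs from compound 2 by 4-hydroxy-5-(hydroxymethyl)oxolan-2-yl in place of 2,3-dihydroxypropyl on an aromatic nitrogen. Within the data shown here, no measured step covers an exchange of this kind, so no direction can be drawn from the numbers. The step is therefore expected to be a 1.1-fold higher number from compound 2 to compound 3 (0.03 log units; within the scatter). Compound 3 is estimated at 420 nM, with a likely range from 150 nM to 1200 nM.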

Compound 3, half-maximal inhibitory concentration: 120 nM
The estimate for compound 3 lay 3.5-fold (0.54 log units) above the measured number, outside the stated range (below it).
By their numbers in this assay, from the lowest: compound 3; then compound 2; then compound 1.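

On the aromatic nitrogen of the five-membered ring with 3 nitrogen, the earlier step exchanged a whole side chain, whereas here only the end group changes: in this assay, 4-hydroxy-5-(hydroxymethyl)oxolan-2-yl replacing 2,3-dihydroxypropyl gives a 3.3-fold lower number from compound 2 to compound 3 (0.51 log units; beyond the scatter). So this position responds to a change that keeps the count of hydrogen-bond donors the same while adding a ring. Nothing available explains this gain. The compounds shown leave open whether the ring, its hydroxyl groups or its stereocentres matter, and how an amine or a carboxylic acid would fare at this position.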